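The compounds below may be only part of what the source reports. "The series", "measured", "known", "first", "only" and "open" are said of these compounds alone.

Measured compounds:
compound 1 `Cc1cc(Nc2ccn(Cc3cccc4ccccc34)n2)n2nc(SCc3ccc(Br)cc3)nc2n1` with 3240 nM
compound 2 `CCCCCc1c(C)nc2nc(SCc3ccc(Cl)cc3)nn2c1Nc1cc(-c2ccccc2)[nH]n1` with 7140 nM
compound 3 `Cc1cc(Nc2cc(-c3ccccc3)[nH]n2)n2nc(SCc3cccc(Br)c3)nc2n1` with 4820 nM

The account follows a single structural step. In a functional assay on MGC-803 cells (Homo sapiens) for inhibition, read by MTT assay, with a stated time of 72 h (on this read-out higher numbers stand for weaker inhibition and lower numbers for stronger inhibition), compound 1 gives 3240 nM, compound 2 gives 7140 nM, and compound 3 gives 4820 nM. Among these three numbers compound 3 holds the second highest. Its nearest neighbour is compound 2, whose number is higher but within the scatter of the method; the furthest is compound 1, whose number is lower, yet that gap too stays within the scatter. Within the data shown here, no pair of these three differs in only one place, so the three values can be read only side by side, and none of them can be called stronger or weaker than another.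

Compound 4 `Cc1cc(Nc2cc(-c3ccccc3)[nH]n2)n2ncnc2n1` has not been measured. It differs from compound 3 in one place: hydrogen in place of (3-bromobenzyl)sulfanyl on an aromatic carbon. Compound 3 is the only anchor. Because compound 3 gives 4820 nM and the change removes a large part of that structure, the estimate for compound 4 is 15000 nM, with a range from 4000 nM to 60000 nM. The expected step of a 3.1-fold higher number from compound 3 to compound 4 (0.49 log units; beyond the scatter) is one toward weaker inhibition, beyond the usual scatter.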

Compound 4, half-maximal inhibitory concentration: 21700 nM
Compound 4: the middle estimate sits 1.4-fold (0.16 log units) below what was measured; the measured number falls inside the stated range.
By their numbers in this assay, from the lowest: compounds 1, 3 and 2 (each within the scatter of the next, the first and the last beyond it); then compound 4.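

In this assay, among these compounds, replacing the (3-bromobenzyl)sulfanyl group with hydrogen on this aromatic carbon, between two ring nitrogen atoms, gives a 4.5-fold higher number from compound 3 to compound 4 (0.65 log units; beyond the scatter) and so provides the first comparison here in which a single change can be read, a modest move toward weaker inhibition. The group therefore counts at this position, yet it is not needed for a measurable read-out, since compound 4, which carries only hydrogen there, still gives 21700 nM in this assay. No measurement offered here accounts for the step, so the result records the size of the change and not its cause.

The compounds shown leave open which part of the departing group goes with the stronger inhibition of compound 3, the sulfur or the bromine-bearing ring, and how a methylsulfanyl group or an amine on the same carbon would compare with hydrogen. They also leave open whether removing the group would give a step of similar size in the settings of compound 1 and compound 2, which differ from compound 3 in more than one place.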